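A few compounds are considered here, and "the series" means these few. Any claim that something is new, unique, unknown or untested is made for them only; others in the source may bear on it.

- compound 1 `O=C(O)[C@H](CO)NC(=O)[C@H]1C[C@H](O)CN1`: > 12 h (a limit)
- compound 2 `O=C(N[C@H](CO)C(=O)O)[C@@H]1C[C@H](O)CN1`: > 12 h (a limit)
- compound 3 `O=C(O)[C@H](CO)NC(=O)[C@@H]1C[C@H](O)CN1`: 0.35 h

In an ADME assay on Jejunum (Mus musculus, strain C57BL/6) for metabolic stability, read by HPLC, with a stated time of 12 h (a higher number here means that the compound lasts longer, a lower number that the compound disappears faster), compound 3 gives 0.35 h, the only actual number among these values. The other two values are limits, and compound 3 lies far beneath them.

The next compound is compound 4 `O=C(N[C@H](CO)C(=O)O)[C@@H]1C[C@@H](O)CN1`, and the change is the two compounds have the same atoms and bonds and differ only in configuration as drawn: 2 of 3 stereo elements differ; a stereocentre at a saturated chain carbon is drawn S in compound 3 and R in compound 4; a stereocentre at a saturated ring carbon is drawn S in compound 3 and R in compound 4. One saturated chain carbon and one saturated ring carbon are each drawn S in compound 3 and R in compound 4.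

The closest evidence is the large step of an at least 34-fold lower number from compound 2 to compound 3 (1.53 log units; beyond the scatter), which turns on the same chain carbon, read here in the opposite direction. The large step of an at least 34-fold lower number from compound 1 to compound 3 (1.53 log units; beyond the scatter) concerns a different ring carbon, so it bears less directly, although it also shows how much a single inversion can matter.

A clear rise is therefore expected, perhaps reaching (the limit of > 12 h in this assay, at which 2 of the 3 values shown sit). The expected change is a 40-fold higher number from compound 3 to compound 4 (1.60 log units; beyond the scatter). For compound 4 the estimated half-life is 14 h, with an expected range of 4 h to 30 h.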

Compound 4, half-life: 0.39 h
For compound 4 the middle estimate is 36-fold (1.56 log units) above the measured one; measured number below the stated range.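

In this assay, among the compounds shown here, inverting one saturated ring carbon alone is enough for a large drop, an at least 30-fold lower number from compound 2 to compound 4 (1.48 log units; beyond the scatter), so this ring carbon matters as much as the chain carbon and the other ring carbon did in the earlier steps. Compound 3 and compound 4 carry two inverted stereocentres relative to each other and still cannot be told apart, a 1.1-fold higher number from compound 3 to compound 4 (0.05 log units; within the scatter), so inverting the chain carbon together with this ring carbon does not bring back the long half-life. The mirror image of compound 1 also lasts far less long, an at least 30-fold lower number from compound 1 to compound 4 (1.48 log units; beyond the scatter), and only the spatial arrangement separates the two: the fact that compounds 1 and 4 differ only in the configuration as drawn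

The step between compound 1 and compound 2 cannot be read, as both values are limits. As far as these compounds go, whether these configurations keep their order with a methyl ester in place of the carboxylic acid, or with a methoxy group in place of the ring hydroxyl, remains open.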